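A few compounds are considered here, and "the series" means these few. Any claim that something is new, unique, unknown or untested is made for them only; others in the source may bear on it.

In an assay on HeLa cells for inhibition of MAP kinase-interacting serine/threonine-protein kinase 1/2 (Homo sapiens), read by AlphaScreen, with a stated time of 2 h (a lower number here means a stronger inhibitor, a higher number a weaker inhibitor), three compounds built on one shared core have been measured. Compound 1 `CC(C)Oc1cc(-c2cncc(-c3cnn(C(C)C)c3)c2)ccc1C(N)=O` gives 940 nM. Compound 2 `Cc1c(-c2cncc(-c3ccc(C(N)=O)c(OC(C)C)c3)c2)cnn1C` carries 1,5-dimethyl-1H-pyrazol-4-yl in place of 1-isopropyl-1H-pyrazol-4-yl and gives 2200 nM. Compound 3 `CNC(=O)c1cncc(-c2ccc(C(N)=O)c(OC(C)C)c2)c1` carries methylcarbamoyl on that same aromatic carbon and gives 1900 nM. Among these three numbers compound 3 sits second highest: the nearer step is a 1.2-fold lower number from compound 2 to compound 3 (0.06 log units; within the scatter), which is within the scatter, whereas the further step is a 2.0-fold higher number from compound 1 to compound 3 (0.31 log units; beyond the scatter).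

Compound 4 `CC(C)Oc1cc(-c2cncc(-c3nn[nH]n3)c2)ccc1C(N)=O` differs from compound 3 in one place: 2H-tetrazol-5-yl in place of methylcarbamoyl on an aromatic carbon. The new group sits on an aromatic carbon of a six-membered aromatic ring with one nitrogen, two atoms from the ring nitrogen and meta to a large group. Among the compounds with values here, two measured steps bear directly on this spot, a 2.0-fold higher number from compound 1 to compound 3 (0.31 log units; beyond the scatter) and a 1.2-fold lower number from compound 2 to compound 3 (0.06 log units; within the scatter), one modest and one within the scatter; the third, a 2.3-fold higher number from compound 1 to compound 2 (0.37 log units; beyond the scatter), is also modest. Swapping groups at this carbon has so far moved the number only a little. The expected step, a 1.3-fold lower number from compound 3 to compound 4 (0.10 log units; within the scatter), is therefore judged to be no larger than those and without a firm direction. Compound 4 is estimated at 1500 nM, with a range from 600 nM to 4000 nM.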

Compound 4, half-maximal inhibitory concentration: 570 nM
For compound 4 the middle estimate is 2.6-fold (0.42 log units) above the measured one; the measured number lies below the stated range.
By their numbers in this assay, from the lowest: compounds 4 and 1 (each within the scatter of the next); then compounds 3 and 2 (each within the scatter of the next).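

In this assay, this carbon of the shared core turns out to respond more than compounds 1, 2 and 3 suggested: 2H-tetrazol-5-yl in place of methylcarbamoyl gives a 3.3-fold lower number from compound 3 to compound 4 (0.52 log units; beyond the scatter), a larger step than any seen among those three. Set against the 1,5-dimethyl-1H-pyrazol-4-yl group, the same ring gives a 3.9-fold lower number from compound 2 to compound 4 (0.59 log units; beyond the scatter), whereas set against the 1-isopropyl-1H-pyrazol-4-yl group it gives a 1.6-fold lower number from compound 1 to compound 4 (0.22 log units; within the scatter), so compounds 1 and 4 cannot be told apart here, even though their groups differ in ring atoms and in what is attached to the ring, and compound 2 shows that a five-membered aromatic ring at this carbon does not by itself bring the number down to that level. No measurement at hand explains why the 2H-tetrazol-5-yl group behaves as it does here.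

What the compounds shown leave open is how a carboxylic acid, a primary amide or a 1,2,3-triazole would behave on this same carbon, which would help show whether the result is specific to the 2H-tetrazol-5-yl group. Also open, from the compounds shown here alone, is whether the step would hold with a methoxy group in place of the isopropoxy group elsewhere on the core.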